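The source may report more compounds than this note shows. Statements on the series, on what has been measured and on what is new or still open speak of the compounds shown alone.

Measured so far:
Compound 1, `ClC1=C(c2nnc(-c3ccccc3)o2)CCCc2ccccc21`: 675 nM in a functional assay on PANC-1 cells (Homo sapiens) for antiproliferative activity, read by sulforhodamine B assay, with a stated time of 48 h; on this read-out higher numbers stand for weaker inhibition of growth and lower numbers for stronger inhibition of growth
Compound 2, `Cc1ccc(-c2nnc(C3=C(Cl)c4ccccc4CCC3)o2)cc1`: 6810 nM
Compound 3, `Cc1cc2c(cc1C)C(Cl)=C(c1nnc(-c3ccccc3)o1)CCC2`: 4120 nM

Compound 4, `Cc1ccc(-c2nnc(C3=C(Cl)c4cc(C)c(C)cc4CCC3)o2)cc1`, has not been measured yet. Compound 4 differs from compound 3 by methyl in place of hydrogen on an aromatic carbon. The same change has been made once already, from compound 1 to compound 2, as methyl in place of hydrogen on an aromatic carbon, and there it gave a 10-fold higher number from compound 1 to compound 2 (1.00 log units; beyond the scatter). The difference between the core of compound 1 and the core of compound 3 is not broken down here. Because compound 3 already gives 4120 nM, and because the earlier step was a 10-fold higher number from compound 1 to compound 2 (1.00 log units; beyond the scatter), compound 4 is expected to show a step of about a 6.1-fold higher number from compound 3 to compound 4 (0.78 log units; beyond the scatter), a little smaller than the earlier one. Compound 4 is therefore estimated at 25000 nM, with a range from 8000 nM to 80000 nM.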

Compound 4, concentration for 50% growth inhibition: 3880 nM
The estimate for compound 4 lay 6.4-fold (0.81 log units) above the measured number; measured number outside the range, below it.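

In this assay, the methyl that turns phenyl into 4-methylphenyl gave a 1.1-fold lower number from compound 3 to compound 4 (0.03 log units; within the scatter) and so made no change that stands out from the scatter on this core. The same change therefore did not carry over from one core to the other: the same change on two cores in this assay, a 10-fold higher number (1.00 log units; beyond the scatter) from compound 1 to compound 2 and a 1.1-fold lower number (0.03 log units; within the scatter) from compound 3 to compound 4, 11-fold (1.03 log units) apart, beyond the scatter of two such steps. This shows that a step measured on one core cannot simply be added to a value on another core in this series, but two pairs do not show which difference between the cores matters or what a further core would do.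

The compounds shown leave open how a different group in the same place, such as an amine or a carboxylic acid, would behave on either core.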